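The compounds below may be only part of what the source reports. "The series", "measured", "known", "first", "only" and "open" are said of these compounds alone.

Among the two compounds measured so far, compound 2 `COc1cc2c(cc1OC)C(=O)/C(=C/c1cc(C)c([N+](=O)[O-])c(C)c1)C2` stands at the highest number: in a functional assay on Jurkat cells (Homo sapiens) for antiproliferative activity, read by MTT assay (a higher number here means a weaker inhibitor, a lower number a stronger inhibitor), compound 2 gives 25000 nM. Its nearest neighbour is compound 1 `COc1cc2c(cc1OC)C(=O)/C(=C/c1cc(C)c(O)c(C)c1)CC2`, which carries a hydroxyl in place of the nitro and a different ring in the shared core; in this assay compound 1 gives 4800 nM, a gap between the two values that lies beyond the scatter. The step to compound 3 `COc1cc2c(cc1OC)C(=O)/C(=C/c1cc(C)c(N)c(C)c1)C2` is a single change: amino in place of nitro on an aromatic carbon. For the measured compounds named here, no pair of measured compounds shows this exchange, so its effect is unknown; the only hint is that compound 1, whose hydrogen-bond donor at this position goes with 4800 nM, sits at the lower number. Compound 3 is therefore expected to move toward a lower number in this assay, by a 2.8-fold lower number from compound 2 to compound 3 (0.44 log units; beyond the scatter), though with wide uncertainty. The estimate for compound 3 is 9000 nM, with a range from 2500 nM to 32000 nM.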

Compound 3, half-maximal inhibitory concentration: 55 nM
The estimate for compound 3 lay 160-fold (2.21 log units) above the measured number, and the stated range ends above it.
By their numbers in this assay, from the lowest: compound 3; then compound 1; then compound 2.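

In this assay, amino in place of nitro gives a 450-fold lower number from compound 2 to compound 3 (2.66 log units; beyond the scatter) through a change at one aromatic carbon, so this position, ortho to two methyl groups and para to a large group, is highly sensitive to what it carries. Compound 1 differs from compound 2 and compound 3 in two places and could not isolate this effect; this pair does, with the shared core held constant. Nothing available accounts for the size of the step.

Going by these compounds, it remains open whether the free amino group itself is needed, or whether a methylamino, dimethylamino or acetamido group on this carbon would serve equally well. The compounds shown also leave open what the two methyl groups contribute, and how hydroxyl would compare with amino on the core of compound 3.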